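A further chloro group on compound 2

The source may hold more compounds than are shown below. What is called first, only, known or untested is meant among the compounds shown, and "the series" means these compounds.

Measured in a functional assay on MCF7 cells (Homo sapiens) for antiproliferative activity, read by MTT assay, with a stated time of 48 h; a lower number here means a stronger inhibitor, a higher number a weaker inhibitor:
Compound 1 `Clc1cc2nc(-c3cn(-c4ccccc4)nc3-c3ccccc3)[nH]c2cc1Cl`: 7560 nM
Compound 2 `COc1ccc(-c2nn(-c3ccccc3)cc2-c2nc3cc(Cl)ccc3[nH]2)cc1`: 1760 nM

Of the two measured compounds, compound 2 has the lower number, and the gap to compound 1 lies beyond the scatter. Compound 3 `COc1ccc(-c2nn(-c3ccccc3)cc2-c2nc3cc(Cl)c(Cl)cc3[nH]2)cc1` departs from compound 2 in one place: chloro in place of hydrogen on an aromatic carbon. This is chloro in place of hydrogen on an aromatic carbon. Within the data shown here, no measured pair shows this change alone, so in this assay only a small step towards a lower number, none beyond the scatter, is expected. The expected change is a 1.2-fold lower number from compound 2 to compound 3 (0.07 log units; within the scatter). For compound 3 the estimated value is 1500 nM, with an expected range of 500 nM to 4500 nM.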

Compound 3, half-maximal inhibitory concentration: 13200 nM
The estimate for compound 3 lay 8.8-fold (0.94 log units) below the measured number; the whole stated range lies below it.
By their numbers in this assay, from the lowest: compound 2; then compounds 1 and 3 (each within the scatter of the next).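

In this assay a chloro group on this aromatic carbon, ortho to a chloro group, is not neutral: the step reads a 7.5-fold higher number from compound 2 to compound 3 (0.88 log units; beyond the scatter) and points towards a weaker inhibitor. With both chloro groups present, the step for methoxy in place of hydrogen reads a 1.7-fold higher number from compound 1 to compound 3 (0.24 log units; within the scatter) and lies within the scatter, so compound 1 and compound 3 cannot be told apart here. No evidence on hand bears on this result. The compounds shown leave open how a fluoro, methyl or amine group would fare on this same carbon.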